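Cytotoxicity of Two Quinolone Cores with an Aryl Swap

The source may hold more compounds than are shown below. What is called first, only, known or untested is meant among the compounds shown, and "the series" means these compounds.

Of the compounds shown here, three have been tested in a functional assay on V79 cells (Cricetulus griseus) for cytotoxicity, read by colony formation; a higher number here means a weaker inhibitor, a lower number a stronger inhibitor. Compound 1 `COc1c(N2CCC(C)(N)C2)c(F)cc2c(=O)c(C(=O)O)cn(C3CC3)c12` gives 38 ug/mL, while compound 2 `COc1c(N2CCC(C)(N)C2)c(F)cc2c(=O)c(C(=O)O)cn(-c3ccc(F)cc3F)c12` gives 250 ug/mL, and compound 3 `CC1CN(c2c(F)cc3c(=O)c(C(=O)O)cn(C4CC4)c3c2C(F)(F)F)CCN1` gives 220 ug/mL. The step of a 6.6-fold higher number from compound 1 to compound 2 (0.82 log units; beyond the scatter) came from one change only, (2,4-difluorophenyl in place of cyclopropyl on an aromatic nitrogen). Compound 4 `CC1CN(c2c(F)cc3c(=O)c(C(=O)O)cn(-c4ccc(F)cc4F)c3c2C(F)(F)F)CCN1` carries the same change on the core of compound 3, as 2,4-difluorophenyl in place of cyclopropyl on an aromatic nitrogen. The difference between the two cores is not broken down here. Because the earlier change produced a 6.6-fold higher number from compound 1 to compound 2 (0.82 log units; beyond the scatter), a step of similar direction is expected here, so that compound 4 is estimated to reach 900 ug/mL in this assay, with a range from 400 ug/mL to 2000 ug/mL. The expected step is a 4.1-fold higher number from compound 3 to compound 4 (0.61 log units; beyond the scatter), and the estimate rests on one prior pair only.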

Compound 4, half-maximal inhibitory concentration: > 500 ug/mL
Compound 4: only a limit was reported; the forecaster's own chance of this, stated with the estimate: 30%; the middle value lies beyond the limit too.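

In this assay, putting 2,4-difluorophenyl in place of cyclopropyl on the aromatic nitrogen of the second core gave an at least 2.2-fold higher number from compound 3 to compound 4 (0.35 log units; beyond the scatter). Compound 4 reads > 500 ug/mL, which is a limit of the assay and not a number. The change therefore moved the number the same way on both cores, but this pair of steps cannot show whether it carries over with the same size: the same change on two cores in this assay, a 6.6-fold higher number (0.82 log units; beyond the scatter) from compound 1 to compound 2 and an at least 2.2-fold higher number (0.35 log units; beyond the scatter) from compound 3 to compound 4; the limit leaves it open whether they differ

As far as these compounds go, whether the same direction holds beyond these two cores remains open. From the compounds shown here alone, it is also open how other groups on that aromatic nitrogen, such as a simple ethyl chain or an unsubstituted phenyl ring, would compare with cyclopropyl and 2,4-difluorophenyl.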